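Ester in place of bromophenyl ketone on the shared core

The source may report more compounds than this note shows. Statements on the series, on what has been measured and on what is new or still open speak of the compounds shown alone.

For the measured compounds named here, compound 2 `O=C(CSCc1nc2cc([N+](=O)[O-])ccc2[nH]1)c1ccc(Br)cc1` gives 1550 nM in a functional assay on MCF7 cells (Homo sapiens) for cytotoxicity, read by MTT assay, with a stated time of 48 h (on this read-out lower numbers stand for stronger inhibition and higher numbers for weaker inhibition), the lowest of the two numbers so far; compound 1 `O=C(CSCc1nc2cc([N+](=O)[O-])ccc2[nH]1)c1ccccc1` gives 18600 nM. Going by the values given here, the only measured step, a 12-fold lower number from compound 1 to compound 2 (1.08 log units; beyond the scatter), shows how much the bromine contributes. Compound 3 `CCOC(=O)CSCc1nc2cc([N+](=O)[O-])ccc2[nH]1` differs from compound 2 by ethoxy in place of 4-bromophenyl on a carbonyl carbon, so the bromine and its ring both leave. Among the compounds with values here, no measured step mirrors this, but the step from compound 1 to compound 2 suggests a large rise; compound 3 is therefore expected at 30000 nM (range 8000 nM to 100000 nM), a step of a 19-fold higher number from compound 2 to compound 3 (1.29 log units; beyond the scatter).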

Compound 3, half-maximal inhibitory concentration: > 100000 nM
Compound 3 was reported as a limit; the forecaster's own chance of this, stated with the estimate: 20%; middle value at least 3.3-fold (0.52 log units) away from the limit.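

Compound 3 yields a limit rather than a number: the limit of > 100000 nM in this assay, at which 1 of the 3 values shown sits. Ethoxy in place of 4-bromophenyl on the carbonyl carbon gives an at least 64-fold higher number from compound 2 to compound 3 (1.80 log units; beyond the scatter). Ethoxy in place of phenyl still gives an at least 5.3-fold higher number from compound 1 to compound 3 (0.73 log units; beyond the scatter), so the aromatic ring at this position matters in this assay even without the bromine.

Going by these compounds, how far compound 3 lies past its limit remains unknown. On these data alone, it also remains open whether a saturated ring such as cyclohexyl, or a carboxylic acid, could replace the aromatic ring on this carbonyl carbon.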